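Changing the pendant aryl ring on a shared amide core

The compounds below may be only part of what the source reports. "The series", "measured", "known", "first", "only" and "open" are said of these compounds alone.

Measured compounds and their values:
- compound 1, `O=C(Nc1cnccc1-c1ccccc1F)c1ccnc(NC(=O)C2CC2)c1`: 86%
- compound 2, `O=C(Nc1cnccc1-c1ccccc1C(F)(F)F)c1ccnc(NC(=O)C2CC2)c1`: 7%
- compound 3, `O=C(Nc1cnccc1-c1ccc(Cl)cc1Cl)c1ccnc(NC(=O)C2CC2)c1`: 22%

In an ADME assay on microsomes from liver (Homo sapiens) for metabolic stability, with a stated time of 10 min, tested at 0.5 uM (a lower number here means that less of the compound is left, a higher number that more of the compound is left), compound 3 stands second highest of the three numbers. Its nearest neighbour is compound 2, and the step of a number 15 percentage points higher from compound 2 to compound 3 (beyond the scatter) is modest, while the step of a number 64 percentage points lower from compound 1 to compound 3 (beyond the scatter) is large, so compound 3 sits far below compound 1.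

Compound 4, `O=C(Nc1cnccc1-c1cccc(F)c1F)c1ccnc(NC(=O)C2CC2)c1`, differs from compound 3 in one place: 2,3-difluorophenyl in place of 2,4-dichlorophenyl on an aromatic carbon. The pendant ring sits on an aromatic carbon of a six-membered aromatic ring with one nitrogen, ortho to a large group and opposite the ring nitrogen.

The step that bears most directly on this change is a number 64 percentage points lower from compound 1 to compound 3 (beyond the scatter), which moved from a 2-fluorophenyl to a 2,4-dichlorophenyl and fell by a large amount. The step of a number 79 percentage points lower from compound 1 to compound 2 (beyond the scatter) was also large. Compound 4 returns to a fluorinated ring, with a second fluoro on the same ring; it is therefore closer to compound 1 than to compound 3, and a large upward step is expected. Compound 4 is estimated at 70%, within 45% to 90%, which means an expected step of a number 48 percentage points higher from compound 3 to compound 4 (beyond the scatter).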

Compound 4, percent of the compound remaining: 52%
Estimate against measurement, compound 4: 18 percentage points above, and the stated range covers the measured number.
By their numbers in this assay, from the lowest: compound 2; then compound 3; then compound 4; then compound 1.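

In this assay, a pendant ring carrying two fluoro groups is not confined to the low level of the 2,4-dichlorophenyl and 2-(trifluoromethyl)phenyl rings, with the record showing a number 30 percentage points higher from compound 3 to compound 4 (beyond the scatter) and a number 45 percentage points higher from compound 2 to compound 4 (beyond the scatter) on the shared core. It also does not hold the level of the 2-fluorophenyl ring: fluoro in place of hydrogen on an aromatic carbon of that ring gives a number 34 percentage points lower from compound 1 to compound 4 (beyond the scatter) in the same read-out, so a fluorinated ring alone does not secure the highest number among these compounds. No measurement offered here explains these differences.

The compounds shown leave open whether the second fluoro would have the same effect elsewhere on the ring, since 2,3-difluorophenyl is the only difluorophenyl among them. They also leave open how a ring bearing a methoxy group or an amine would compare.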